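Swapping an aromatic ring for a heptyl chain

The compounds below may be only part of what the source reports. "The series", "measured", "known", "first", "only" and "open" are said of these compounds alone.

In a functional assay on A549 cells (Homo sapiens) for inhibition, read by MTT assay, with a stated time of 48 h (on this read-out higher numbers stand for weaker inhibition and lower numbers for stronger inhibition), compound 1 (`O=[N+]([O-])c1ccc2[nH]cc(C(c3ccc(Cl)cc3)c3c[nH]c4ccc([N+](=O)[O-])cc34)c2c1`) gives > 100000 nM as a limit, not a number. Compound 2 (`O=[N+]([O-])c1ccc2[nH]cc(C(c3ccc(Br)cc3)c3c[nH]c4ccc([N+](=O)[O-])cc34)c2c1`) gives > 100000 nM as a limit as well. Compound 3 (`O=[N+]([O-])c1ccc(C(c2c[nH]c3ccc([N+](=O)[O-])cc23)c2c[nH]c3ccc([N+](=O)[O-])cc23)cc1`) likewise gives > 100000 nM as a limit. What the series offers so far is the limit of > 100000 nM in this assay, at which 3 of the 3 values shown sit, and nothing firmer.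

Compound 4 (`CCCCCCCC(c1c[nH]c2ccc([N+](=O)[O-])cc12)c1c[nH]c2ccc([N+](=O)[O-])cc12`) has not been measured yet. It carries heptyl in place of 4-nitrophenyl on a saturated chain carbon bound to two aromatic carbons. The measured steps that bear on this are a step that the two limits leave unreadable from compound 1 to compound 2 along with a step that the two limits leave unreadable from compound 1 to compound 3 and a step that the two limits leave unreadable from compound 2 to compound 3 and none of them has a readable size. Each of them swaps one group on an aromatic carbon, whereas this change removes the whole 4-nitrophenyl, so they are only a loose guide.

The expectation for compound 4 is weak inhibition, resting on compound 3 and its limit of > 100000 nM alone. The expected change is an at least 1.2-fold lower number from compound 3 to compound 4 (0.09 log units; that floor lies within the scatter) in this assay and it is small or unreadable, with any shift more likely towards stronger inhibition. For compound 4 the estimated value is 80000 nM with an expected range from 15000 nM to 200000 nM and a real chance of another limit.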

Compound 4, half-maximal inhibitory concentration: 12500 nM
The estimate for compound 4 lay 6.4-fold (0.81 log units) above the measured number; the whole stated range lies above it.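

In this assay, heptyl in place of 4-nitrophenyl on the saturated chain carbon bound to two aromatic carbons gives an at least 8.0-fold lower number from compound 3 to compound 4 (0.90 log units; beyond the scatter), and this is a step whose direction can be read. Heptyl in place of 4-bromophenyl gives an at least 8.0-fold lower number from compound 2 to compound 4 (0.90 log units; beyond the scatter), and heptyl in place of 4-chlorophenyl gives an at least 8.0-fold lower number from compound 1 to compound 4 (0.90 log units; beyond the scatter), whereas the swaps among chloro, bromo and nitro on an aromatic carbon cannot be read. This position therefore gives a measurable number once the whole aromatic ring is replaced by a chain, something the ring-bearing compounds could not show, as they stop at one shared limit: the limit of > 100000 nM in this assay, at which 3 of the 4 values shown sit.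

As far as these compounds go, these steps are only minimum sizes, so the true distance between compound 4 and the ring-bearing compounds stays unknown. The compounds shown also do not separate the loss of the aromatic ring from the gain of the chain, so it remains open whether a cyclohexyl ring, a shorter butyl chain, a longer dodecyl chain or a chain ending in an amine would give a lower or a higher number than compound 4.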